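The compounds below may be only part of what the source reports. "The series", "measured", "known", "first", "only" and "open" are said of these compounds alone.

Compound 1 `Nc1nc(Cl)c2ncn(Cc3ccccc3CCl)c2n1` is the starting point for this step. For the measured compounds named here, in a functional assay on SF-539 cells (Homo sapiens) for cytotoxicity, read by sulforhodamine B assay, with a stated time of 48 h (on this read-out lower numbers stand for higher toxicity in this test and higher numbers for lower toxicity in this test), compound 1 gives 81300 nM, the highest of the three numbers measured so far. Compound 3 `ClCc1ccc(Cn2cnc3c(Cl)nc(Cl)nc32)cc1` gives 56200 nM in this assay, within the scatter of compound 1, while compound 2 `ClCc1ccccc1Cn1cnc2nc(Cl)nc(Cl)c21` gives 8310 nM, beyond the scatter. Compound 4 `ClCc1ccccc1Cn1cnc2c(Cl)nc(Cl)nc21` has not yet been measured in this assay. Change from compound 1 to compound 4: chloro in place of amino on an aromatic carbon. Compound 2 and compound 3 also carry chloro in place of amino on that aromatic carbon, and their numbers sit at or below compound 1, so a step toward lower numbers is expected here, estimated as a 2.7-fold lower number from compound 1 to compound 4 (0.43 log units; beyond the scatter). For compound 4 the expected value in this assay is 30000 nM, within a range of 8000 nM to 90000 nM.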

Compound 4, concentration lethal to 50% of the cells: 5620 nM
Compound 4: middle estimate off by 5.3-fold (0.73 log units), on the high side; the whole stated range lies above it.
By their numbers in this assay, from the lowest: compounds 4 and 2 (each within the scatter of the next); then compounds 3 and 1 (each within the scatter of the next).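

In this assay, for the compounds shown here, chloro in place of amino on this aromatic carbon, between two ring nitrogen atoms, gives a 14-fold lower number from compound 1 to compound 4 (1.16 log units; beyond the scatter) and is the first step that isolates a single change. The earlier compounds shown here offered no pair differing in one place, so this position could not be read alone until now. No measurement at hand accounts for the size of this step.

On these data alone, whether methoxy, fluoro or a methylamino group on this carbon would sit nearer compound 1 or compound 4 remains open. Also open, as far as these compounds go, is whether the same change gives a similar step when the rest of the molecule differs.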